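Compound 2 to compound 3: a first reading awaited

The source may report more compounds than this note shows. Statements on the series, on what has been measured and on what is new or still open speak of the compounds shown alone.

For the measured compounds named here, the series offers one numerical reading in an ADME assay on MDCK cells (Canis lupus familiaris) for cytotoxicity, with a stated time of 48 h (a lower number here means that less compound is tolerated, a higher number that more compound is tolerated), and no measured step. Compound 1 `CCC(CC)O[C@@H]1C=C(S(=O)(=O)CCc2ccncc2)C[C@H](NC(=N)N)[C@H]1NC(C)=O` reads > 100000 nM there, and this entry is a limit of the assay and not a number. Compound 2 `CCC(CC)O[C@@H]1C=C(S(=O)(=O)OCCCc2ccccc2)C[C@H](N)[C@H]1NC(C)=O` gives "not determined" (no result reported) as its entry, so it provides no starting point on the scale. The next structure is compound 3 `CCC(CC)O[C@@H]1C=C(S(=O)(=O)OCCCc2ccccc2)C[C@H](NC(=N)N)[C@H]1NC(C)=O` and it has not yet been measured. The structural change is a group of 3 heavy atoms (1 carbon, 2 nitrogen; no ring) in place of a hydrogen atom, on an amine nitrogen and it replaces a hydrogen atom on an amine nitrogen. Going by the values given here, no step can be sized from compound 2, so no shift beyond the usual scatter is expected, in either direction. The only anchor is the limit of > 100000 nM in this assay, at which 1 of the 2 values shown sits, and it belongs to compound 1. Compound 3 is expected in this assay at 100000 nM with an estimated range of 40000 nM to 200000 nM and a report as a limit is the likely outcome.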

Compound 3, half-maximal cytotoxic concentration: > 100000 nM
Compound 3: no number, only a limit; the forecaster's own chance of this, stated with the estimate: 75%; the middle value sits exactly at the limit.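

In this assay compound 3 gives > 100000 nM, a limit and not a number. No step from compound 1 to compound 3 can be read, since both entries are limits: the limit of > 100000 nM in this assay, at which 2 of the 3 values shown sit.

The compounds shown leave open where either compound would fall on a numerical scale.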